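This account rests on a few compounds, and the source may have more. Where it says the series, first, only, none or still open, it means among the compounds named here.

Three close analogues of one shared core have been tested in a functional assay on EL4 cells (Mus musculus) for inhibition, tested at 100 uM; on this read-out higher numbers stand for more inhibition at the one concentration tested (going by the name of the read-out) and lower numbers for less inhibition. Compound 1 `Clc1[nH]ccc2ncnc1-2` carries a chloro group on an aromatic carbon of that core. In this assay compound 1 gives < 5%, which is a limit of the assay rather than a number. Compound 2 `Sc1[nH]ccc2ncnc1-2` has a sulfanyl group in the same place. In this assay compound 2 gives < 5%, again a limit and not a number. Among the measured compounds shown here, compound 3 `CN(C)c1[nH]ccc2ncnc1-2` carries a dimethylamino group there, and in this assay compound 3 gives 25%, the only real number among the three values shown. Because both of the other compounds sit at the limit of < 5% in this assay, at which 2 of the 3 values shown sit, the step that the two limits leave unreadable from compound 1 to compound 2 cannot be read. The two remaining steps are readable: a number at least 20 percentage points higher from compound 1 to compound 3 (beyond the scatter) and a number at least 20 percentage points higher from compound 2 to compound 3 (beyond the scatter).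

Compound 4 `[N-]=[N+]=Nc1[nH]ccc2ncnc1-2` is the next compound to be measured. azido in place of dimethylamino on an aromatic carbon Of the three groups measured on this carbon, only dimethylamino gave a number, while chloro and sulfanyl both gave limits. For the measured compounds named here, no measured step shows how azido behaves, so the change carries a clear risk of falling back toward the limit. The expected step is a number 15 percentage points lower from compound 3 to compound 4 (beyond the scatter). For compound 4 the estimated inhibition in this assay is 10%, within a range from 3% to 25%.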

Compound 4, a percentage reported as inhibition, at one concentration (the size of the read-out at that concentration, not a potency): < 5%
Compound 4: a limit, no number; the forecaster's own chance of this, stated with the estimate: 40%; at least 5 percentage points between middle value and limit.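

Swapping the dimethylamino group of compound 3 for azido does not keep the inhibition seen on this aromatic carbon: in this assay the change gives a number at least 20 percentage points lower from compound 3 to compound 4 (beyond the scatter). The two groups match in the counts of heavy atoms, hydrogen-bond donors and hydrogen-bond acceptors, and neither has a ring or a net charge, so a match in those counts was not enough to keep the number; they differ in that azido is made only of nitrogen and has double bonds outside aromatic rings. Dimethylamino is now the only one of the four groups on this carbon that gives a real number, and the steps from compound 1 and from compound 2 to compound 4 cannot be read, because those values all sit at a limit rather than at numbers: the limit of < 5% in this assay, at which 3 of the 4 values shown sit.

As far as these compounds go, it remains open whether the inhibition needs both methyl groups, as a simple amine or a methylamino group would show. Also open, from the compounds shown here alone, is whether a larger amine, such as diethylamino or morpholine, would give more or less inhibition than compound 3.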